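This account rests on a few compounds, and the source may have more. Where it says the series, first, only, none or still open, it means among the compounds named here.

Of the compounds shown here, two have been measured in a functional assay on BHK cells for positive allosteric modulation of metabotropic glutamate receptor 5 (Homo sapiens), read by FLIPR and calcium flux; a lower number here means that less compound is needed, a higher number that more compound is needed for the effect. Compound 1 `O=C(NC1CCCC1)c1ccc(C#Cc2ccccc2)nc1` gives 30 nM in this assay. Compound 2 `O=C(c1ccc(C#Cc2ccccc2)nc1)N1CCOCC1` gives 990 nM in this assay, the highest of the two numbers, and the only shown step, a 33-fold higher number from compound 1 to compound 2 (1.52 log units; beyond the scatter), separates it from compound 1. Compound 3 `O=C(c1ccc(C#Cc2ccccc2)nc1)N1CCSCC1` has not yet been measured. It differs from compound 2 in one place: thiomorpholin-4-yl in place of morpholin-4-yl on a carbonyl carbon. Among the measured compounds shown here, no measured step concerns this kind of exchange; the single step from compound 1 to compound 2 swaps a cyclopentylamino for a morpholin-4-yl group and therefore says little about replacing one oxygen in a six-membered ring by sulfur. With nothing pointing in either direction, the expectation for compound 3 is a step of about a 1.1-fold lower number from compound 2 to compound 3 (0.04 log units; within the scatter) in this assay, that is, no change beyond the usual scatter. Compound 3 is therefore estimated at 900 nM in this assay, with a likely range from 300 nM to 3000 nM.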

Compound 3, half-maximal effective concentration: 46 nM
The estimate for compound 3 lay 20-fold (1.29 log units) above the measured number; measured number outside the range, below it.
By their numbers in this assay, from the lowest: compounds 1 and 3 (each within the scatter of the next); then compound 2.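

Swapping just one ring atom, the oxygen of morpholin-4-yl for the sulfur of thiomorpholin-4-yl, on a carbonyl carbon gives a 22-fold lower number from compound 2 to compound 3 (1.33 log units; beyond the scatter) in this assay, so this position responds strongly even to a change that leaves the ring size and the heavy-atom count as they were. The other new comparison, a 1.5-fold higher number from compound 1 to compound 3 (0.19 log units; within the scatter), shows that a six-membered ring can take the place of cyclopentylamino without a difference beyond the scatter, even though compound 3 lacks the amide hydrogen; the loss of that hydrogen therefore cannot by itself account for the large gap between compound 1 and compound 2. Nothing available here explains why sulfur and oxygen differ so much at this position.

From the compounds shown here alone, it remains open whether sulfur is specifically favourable or oxygen specifically unfavourable, a question that a piperidin-1-yl group, with a plain carbon in that ring place, could help to answer. A piperazin-1-yl group, with a ring nitrogen there, would test the same position with another atom.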